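The compounds below may be only part of what the source reports. "The series", "measured", "known", "first", "only" and "open" are said of these compounds alone.

Measured compounds:
Compound 1 `CCCCN(CC)c1nc(C)nc2c(-c3ccc(OC)cc3C)c(C)nn12` — 2.3 nM in an assay on cell membranes for displacement of a labelled ligand from corticotropin-releasing factor receptor 1 (Rattus norvegicus); on this read-out higher numbers stand for weaker inhibition and lower numbers for stronger inhibition
Compound 2 `CCCN(CC1CC1)c1nc(C)nc2c(-c3ccc(OC)cc3C)c(C)nn12` — 1.96 nM

Both measured compounds were tested in this assay. Compound 1 gives 2.3 nM and compound 2 gives 1.96 nM; the step of a 1.2-fold lower number from compound 1 to compound 2 (0.07 log units; within the scatter) means the two numbers cannot be told apart, so compound 1 stands with its closest neighbour at essentially the same level. That step changes the amine group on the shared core, not the aromatic ring that carries the methoxy group.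

Compound 3 `CCCCN(CC)c1nc(C)nc2c(-c3c(C)cc(OC)cc3C)c(C)nn12` differs from compound 1 by methyl in place of hydrogen on an aromatic carbon. No measured step touches this position: the only step shown, a 1.2-fold lower number from compound 1 to compound 2 (0.07 log units; within the scatter), lies at the amine, and a step there says nothing about a methyl added to the aromatic ring ortho to a large group and meta to a methoxy group. In the absence of a comparable change, the expectation for this assay rests on compound 1 alone, and the step of a 1.1-fold higher number from compound 1 to compound 3 (0.04 log units; within the scatter) is estimated as lying within the scatter. Compound 3 is therefore expected to give about 2.5 nM, in a range from 0.8 nM to 8 nM.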

Compound 3, half-maximal inhibitory concentration: 4.22 nM
For compound 3 the middle estimate is 1.7-fold (0.23 log units) below the measured one; low and high end bracket the measured number.
By their numbers in this assay, from the lowest: compounds 2, 1 and 3 (each within the scatter of the next, the first and the last beyond it).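

In this assay, methyl in place of hydrogen on this aromatic carbon, ortho to a large group and meta to a methoxy group, gives a 1.8-fold higher number from compound 1 to compound 3 (0.26 log units; within the scatter) and so cannot be told apart from ordinary variation between repeat measurements. For the compounds shown here, this is the first information here about the aromatic ring itself, as the earlier step concerned only the amine: with the butyl(ethyl)amino group in place, this carbon can carry a methyl group with no difference that this read-out can resolve. No other measurement bears on this result, so the data offer no explanation of it.

As far as these compounds go, what a larger or different group on the same aromatic carbon, such as an ethyl group, a chlorine atom or a hydroxyl group, would do remains open, so one methyl group does not show how much room for change this position allows. From the compounds shown here alone, it is also open whether the same methyl group would give a similar result alongside the (cyclopropylmethyl)(propyl)amino group of compound 2, since the change at the ring has been seen with only one amine.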